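The source may report more compounds than this note shows. Statements on the series, on what has been measured and on what is new or still open speak of the compounds shown alone.

Working notes on the series. In a functional assay on PC-3 cells (Homo sapiens) for antiproliferative activity, read by MTT assay, with a stated time of 72 h (a lower number here means a stronger inhibitor, a higher number a weaker inhibitor), compound 1 `COc1ccc(NC(=S)Nc2nc(C(=O)NCc3ccccc3)cs2)cc1` gives 39300 nM and compound 2 `O=C(NCc1ccccc1)c1csc(NC(=S)Nc2ccc(Cl)cc2)n1` gives 51300 nM. Compound 3 `CCOC(=O)c1csc2nc(CN3CCN(Cc4ccccc4)CC3)c(-c3ccc(C)cc3)n12`, built on a different core, has no number here, only a limit of > 100000 nM.

Compound 4 `CCOC(=O)c1csc2nc(CN3CCN(Cc4ccccc4)CC3)c(-c3ccc(OC)cc3)n12` carries one change relative to compound 3: methoxy in place of methyl on an aromatic carbon. This is methoxy in place of methyl on an aromatic carbon, para to a large group.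

Going by the values given here, the one measured step that involves methoxy on an aromatic carbon is a 1.3-fold higher number from compound 1 to compound 2 (0.12 log units; within the scatter), with chloro in place of methoxy. It is a different exchange on a different core, so it is only weak guidance, but it gives no sign of a large effect. No step beyond the scatter is therefore expected in this assay, in either direction, and compound 4 may also be reported only as a limit. The estimated step is a number no higher from compound 3 to compound 4 (the limit leaves the size open). For compound 4 the expected value is 100000 nM, with an estimated range of 40000 nM to 200000 nM.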

Compound 4, half-maximal inhibitory concentration: 29400 nM
For compound 4 the middle estimate is 3.4-fold (0.53 log units) above the measured one, outside the stated range (below it).
By their numbers in this assay, from the lowest: compounds 4, 1 and 2 (each within the scatter of the next). At a limit, above all of these: compound 3.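

Going by these compounds alone, on the shared core, 4-methylphenyl to 4-methoxyphenyl gives the only step beyond the scatter so far in this assay: an at least 3.4-fold lower number from compound 3 to compound 4 (0.53 log units; beyond the scatter). Within the data shown here, the one earlier step, a 1.3-fold higher number from compound 1 to compound 2 (0.12 log units; within the scatter), involves methoxy on an aromatic carbon of another core and stays within the scatter, so this position on the present core shows a response that the earlier pair did not. Compound 3 stands only at a limit, so the full size of the step remains open: the limit of > 100000 nM in this assay, at which 1 of the 4 values shown sits.

On these data alone, whether hydroxy, ethoxy or a dimethylamino group at this place on the ring would read like methoxy or like methyl stays open. Also open, as far as these compounds go, is whether chloro on this core would match methoxy, as it does within the scatter on the core of compound 1.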